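Amino for chloro on the fused core of compound 1

The compounds below may be only part of what the source reports. "The series", "measured", "known", "first", "only" and "open" are said of these compounds alone.

Working notes on a small set of chloromethylbenzyl purine-type compounds tested in a functional assay on M14 cells (Homo sapiens) for cytotoxicity, read by sulforhodamine B assay, with a stated time of 48 h; a higher number here means that more compound is tolerated, a lower number that less compound is tolerated. Compound 1 `ClCc1ccccc1Cn1cnc2c(Cl)nc(Cl)nc21` gives 5750 nM in this assay, the lowest of the two numbers in hand. Compound 3 `ClCc1cccc(Cn2cnc3c(Cl)ncnc32)c1` gives 6600 nM, which sits within the scatter of compound 1, so the two are not distinguished. Compound 2 `Nc1nc(Cl)c2ncn(Cc3ccc(CCl)cc3)c2n1` reaches only a limit of the assay, > 100000 nM, and no number is known for it; this is the case described by the limit of > 100000 nM in this assay, at which 1 of the 3 values shown sits.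

The step under consideration goes from compound 1 to compound 4 `Nc1nc(Cl)c2ncn(Cc3ccccc3CCl)c2n1`, not yet measured. The change is amino in place of chloro on an aromatic carbon. For the measured compounds named here, no measured pair differs in this one place alone, so nothing is known directly about its size. Compound 2 carries the same amino-and-chloro pattern on the core as compound 4 but a differently substituted benzyl group, and it gives only a limit, which makes a rise toward less tolerated compound, beyond the scatter, the more likely direction. For compound 4 the expected value in this assay is 30000 nM, between 7000 nM and 130000 nM, an estimated step of a 5.2-fold higher number from compound 1 to compound 4 (0.72 log units; beyond the scatter).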

Compound 4, concentration lethal to 50% of the cells: > 100000 nM
Compound 4 ended at the assay's limit; the forecaster's own chance of this, stated with the estimate: 40%; at least 3.3-fold (0.52 log units) between middle value and limit.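

In this assay, for the compounds shown here, amino in place of chloro on an aromatic carbon, between two ring nitrogen atoms and para to a fused ring, gives an at least 17-fold higher number from compound 1 to compound 4 (1.24 log units; beyond the scatter), the first reading of this change in a pair that differs in this one place alone. Compound 4 gives > 100000 nM, which is a limit of the assay and not a number, so the step shows a direction and a minimum size but no full size. Compound 2 and compound 4 carry differently substituted benzyl groups, yet both stand at the same limit, so with amino in this place the benzyl difference cannot be read from these compounds: the limit of > 100000 nM in this assay, at which 2 of the 4 values shown sit.

Open, on these data alone, is whether a methoxy or a dimethylamino group in the same place would shift the number as amino does, or whether a value within the range of the assay can be reached with any nitrogen group here. Also open, as far as these compounds go, is whether the step depends on the chloro group that stays on the core, meta to this place, and on the benzyl group of compound 1.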